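The source may hold more compounds than are shown below. What is called first, only, known or untested is meant among the compounds shown, and "the series" means these compounds.

Compound 1 `Cn1c(Cc2ccccc2C(F)(F)F)nc(C(=O)NCc2cccnc2)c(O)c1=O` gives > 100000 nM in an ADME assay on HepG2 cells (Homo sapiens) for cytotoxicity, in the presence of a further agent that is not named here (a lower number here means a stronger inhibitor, a higher number a weaker inhibitor), which is a limit of the assay and not a number.
Compound 2 `CN(Cc1ccccc1)C(=O)c1nc(Cc2ccccc2C(F)(F)F)n(C)c(=O)c1O` gives > 100000 nM in this assay, again a limit.
Compound 3 `CC(c1ccccc1C(F)(F)F)c1nc(C(=O)NCc2ccccc2)c(O)c(=O)n1C` gives > 100000 nM in this assay, also a limit.

Compound 1 therefore stands at the edge of what this assay can report, and so do the two compounds measured beside it: the limit of > 100000 nM in this assay, at which 3 of the 3 values shown sit. Within the data shown here, the one step between measured compounds that differ in a single place, a step that the two limits leave unreadable from compound 1 to compound 2, is left unreadable by the two limits. Compound 4 `Cn1c(Cc2ccccc2C(F)(F)F)nc(C(=O)NCc2ccccc2F)c(O)c1=O` differs from compound 1 by 2-fluorophenyl in place of pyridin-3-yl on a saturated chain carbon bound to an amide-type nitrogen. No measured step bears on this change, and no readable step of any size is known among these compounds. Compound 4 is expected to give 150000 nM, with a range from 100000 nM to 500000 nM. The expected step that the limit leaves unreadable from compound 1 to compound 4 is accordingly estimated to stay within the scatter.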

Compound 4, half-maximal inhibitory concentration: > 100000 nM
Compound 4 gave a limit, no number; the forecaster's own chance of this, stated with the estimate: 90%; the middle value is on the limit's open side.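

Compound 4 gives only a limit, so its steps from compound 1 and from compound 2 cannot be read: the limit of > 100000 nM in this assay, at which 4 of the 4 values shown sit. The compounds shown leave open where the true values lie in this assay, and so whether any of these changes alters them.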